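Swapping hydroxy for carboxy on an anilide side arm

A few compounds are considered here, and "the series" means these few. Any claim that something is new, unique, unknown or untested is made for them only; others in the source may bear on it.

The measurements so far come from an assay on isolated protein for inhibition of Apoptosis regulator Bcl-2 (Homo sapiens), read by fluorescence polarization, with stated times of 5 min and 10 min; a lower number here means a stronger inhibitor, a higher number a weaker inhibitor. Compound 1 `CC1(C)CCCC2=C1C[C@@H](C(=O)O)[C@H](c1ccccc1)C2` carries an acid directly on its ring; in this assay compound 1 reaches only the limit > 23000 nM. Compound 2 `CC(C)=CCCC1=CC[C@H](C(=O)Nc2ccc(O)cc2)[C@@H](c2ccccc2)C1` carries the acid as an amide to a hydroxyphenyl group; compound 2 likewise stops at the limit > 23000 nM. Compound 3 `CC(C)=CCCC1=CC[C@@H](C(=O)Nc2ccc(O)cc2)[C@H](c2ccccc2)C1` is the mirror image of compound 2; in this assay compound 3 also gives only the limit > 23000 nM. Among the measured compounds shown here, the one step between measured compounds, a step that the two limits leave unreadable from compound 2 to compound 3, cannot be sized because of the limit of > 23000 nM in this assay, at which 3 of the 3 values shown sit, and because the fact that compounds 2 and 3 differ only in the configuration as drawn it concerns only the handedness of the molecule, not its groups.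

Compound 4 `CC(C)=CCCC1=CC[C@H](C(=O)Nc2ccc(C(=O)O)cc2)[C@@H](c2ccccc2)C1` differs from compound 2 by carboxy in place of hydroxy on an aromatic carbon. For the measured compounds named here, no measured step touches this change, and nothing measured rises above the limit, so there is no basis for expecting a gain beyond the scatter in this assay. The expectation for compound 4 is therefore a value near the limit again: an estimated 30000 nM, within a range of 6000 nM to 150000 nM, which corresponds to an expected step that the limit leaves unreadable from compound 2 to compound 4.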

Compound 4, inhibition constant: > 23000 nM
Compound 4 was reported as a limit; the forecaster's own chance of this, stated with the estimate: 80%; the middle value lies beyond the limit too.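

In this assay compound 4 gives only a limit, > 23000 nM. No step from compound 2 to compound 4 can be read, because both compounds stop at the same limit: the limit of > 23000 nM in this assay, at which 4 of the 4 values shown sit.

The compounds shown leave open whether carboxy in place of hydroxy on the aromatic carbon changes inhibition at all, and how strong any of these compounds really is.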